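Compound 3: a long chain replaces hydroxycarbamoyl

The source may hold more compounds than are shown below. What is called first, only, known or untested is meant among the compounds shown, and "the series" means these compounds.

In a functional assay on MCF7 cells (Homo sapiens) for inhibition, read by MTT assay, with a stated time of 72 h (on this read-out lower numbers stand for stronger inhibition and higher numbers for weaker inhibition), compound 1 `Nc1nc2cc(-c3nn(CCC(=O)NO)c4ncnc(N)c34)ccc2o1` gives > 100000 nM, a limit and not a number. In this assay compound 2 `Nc1nc2cc(-c3nn(CC(=O)NO)c4ncnc(N)c34)ccc2o1` gives > 100000 nM, likewise only a limit. Compound 2 therefore has no numerical position in this series, and the evidence is the limit of > 100000 nM in this assay, at which 2 of the 2 values shown sit.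

Compound 3 `CNC(=O)CCCCCCCn1nc(-c2ccc3oc(N)nc3c2)c2c(N)ncnc21` differs from compound 2 as follows: 6-(methylcarbamoyl)hexyl in place of hydroxycarbamoyl on a saturated chain carbon bound to an aromatic nitrogen. In words, 6-(methylcarbamoyl)hexyl stands in place of hydroxycarbamoyl on a saturated chain carbon bound to an aromatic nitrogen.

Among the compounds with values here, the one measured step, a step that the two limits leave unreadable from compound 1 to compound 2, has no readable size and sets no scale for this change. Some move toward stronger inhibition in this assay is expected, though with low confidence, and another limit remains quite possible. The expected step is an at least 5.0-fold lower number from compound 2 to compound 3 (0.69 log units; beyond the scatter). For compound 3 the estimated value is 20000 nM, with an expected range of 1000 nM to 100000 nM.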

Compound 3, half-maximal inhibitory concentration: 7220 nM
For compound 3 the middle estimate is 2.8-fold (0.44 log units) above the measured one, within the range that was stated.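

In this assay, within the data shown here, 6-(methylcarbamoyl)hexyl in place of hydroxycarbamoyl on a saturated chain carbon bound to an aromatic nitrogen gives an at least 13-fold lower number from compound 2 to compound 3 (1.14 log units; beyond the scatter), the first step with a readable lower bound. Read as 5-(methylcarbamoyl)pentyl in place of hydroxycarbamoyl on a saturated chain carbon, two bonds along the chain from an aromatic nitrogen, the change gives an at least 13-fold lower number from compound 1 to compound 3 (1.14 log units; beyond the scatter). This chain position can therefore carry a change that brings the series to a measured number, and compound 3 alone has a numerical position, the other compounds remaining at a limit: the limit of > 100000 nM in this assay, at which 2 of the 3 values shown sit.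

The change alters chain length and end group together, and the compounds shown do not separate the two. A 6-(hydroxycarbamoyl)hexyl chain, or a chain of the same length ending in a carboxylic acid or an amine, would bear on that question.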